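A few compounds are considered here, and "the series" means these few. Any claim that something is new, unique, unknown or untested is made for them only; others in the source may bear on it.

Among the measured compounds shown here, compound 2, `COc1ccc(S(=O)(=O)c2nc3ccccc3nc2Nc2cc(OC)c(OC)c(OC)c2)cc1`, stands lowest of the two numbers so far in a functional assay on HL-60 cells (Homo sapiens) for cytotoxicity, read by MTT assay, with a stated time of 72 h; a higher number here means a weaker inhibitor, a lower number a stronger inhibitor: compound 2 gives 680 nM, while compound 1, `COc1ccc(S(=O)(=O)c2nc3ccccc3nc2Nc2cc(OC)cc(OC)c2)cc1`, gives 1710 nM. For the measured compounds named here, the one step between them, a 2.5-fold lower number from compound 1 to compound 2 (0.40 log units; beyond the scatter), concerns methoxy in place of hydrogen on an aromatic carbon of the aniline ring. Compound 3, `COc1cc(Nc2nc3ccccc3nc2S(=O)(=O)c2ccc(F)cc2)cc(OC)c1OC`, differs from compound 2 elsewhere: fluoro in place of methoxy on an aromatic carbon. Going by the values given here, no measured step touches the sulfonyl-bearing ring, so the step from compound 1 to compound 2 gives only indirect guidance; it shows that the potency in this assay moves modestly with substituent changes, but says nothing about whether fluoro can stand in for methoxy here. Compound 3 is therefore expected to sit close to compound 2, with a step of a 1.1-fold higher number from compound 2 to compound 3 (0.04 log units; within the scatter) that may well lie within the scatter, and compound 3 is estimated at 750 nM, in a range from 250 nM to 2200 nM.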

Compound 3, half-maximal inhibitory concentration: 4790 nM
Beside the measured number, compound 3's estimate is 6.4-fold (0.81 log units) below it, and the stated range ends below it.
By their numbers in this assay, from the lowest: compound 2; then compound 1; then compound 3.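

Compound 3 shows that the sulfonyl-bearing ring matters in this assay: fluoro in place of methoxy, para to a large group, gives a 7.0-fold higher number from compound 2 to compound 3 (0.85 log units; beyond the scatter) with the rest of the molecule unchanged. At this position, fluoro therefore does not stand in for methoxy, and the aniline ring is not the only place where a single change moves the number beyond the scatter. No measurement given here accounts for this rise.

The compounds shown leave open whether an amine, a chloro group or a carboxylic acid at this position would stay near compound 2 or move toward compound 3. They also leave open whether 4-methoxyphenyl to 4-fluorophenyl would give a similar step on the aniline ring of compound 1.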